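The source may report more compounds than this note shows. Statements on the series, on what has been measured and on what is new or still open speak of the compounds shown alone.

In an ADME assay on cells (Homo sapiens) for cytotoxicity, read by polymerase chain reaction, with a stated time of 3 days (a lower number here means that less compound is tolerated, a higher number that more compound is tolerated), compound 1 `Cc1nc(N(C)C)nc(N[C@@H]2C[C@H](CO)[C@@H](O)[C@H]2O)c1-c1nc2cnccc2s1` gives 25000 nM, compound 2 `Cc1nc(NCC2CCN(C)CC2)nc(N[C@@H]2C[C@H](CO)[C@@H](O)[C@H]2O)c1-c1nc2cnccc2s1` gives 25000 nM and compound 3 `Cc1nc(NCc2ccccc2)nc(N[C@@H]2C[C@H](CO)[C@@H](O)[C@H]2O)c1-c1nc2cnccc2s1` gives 25000 nM. Compound 3 therefore stands level with the other two at the digits shown.

The next structure, compound 4 `Cc1ccc([C@@H](C)Nc2nc(C)c(-c3nc4cnccc4s3)c(N[C@@H]3C[C@H](CO)[C@@H](O)[C@H]3O)n2)cc1`, differs from compound 3 as follows: 1-(4-methylphenyl)ethyl in place of benzyl on a nitrogen on an aromatic ring. Cut one bond further out, this reads benzylamino to (1-(4-methylphenyl)ethyl)amino, and the entering group brings 1 defined stereocentre.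

The measured steps that bear on this change all concern the same substituent on the shared core: no change at the digits printed from compound 1 to compound 3 (within the scatter), no change at the digits printed from compound 1 to compound 2 (within the scatter) and no change at the digits printed from compound 2 to compound 3 (within the scatter). All three lie within the scatter, even though the groups exchanged differ widely. Among the measured compounds shown here, no measured step alters the benzyl group itself, so the evidence is indirect. No step beyond the scatter is expected in this assay, and neither direction is favoured.

The expected result is no change at the digits printed from compound 3 to compound 4 (within the scatter). For compound 4 the estimated value is 25000 nM, with an expected range from 12000 nM to 40000 nM.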

Compound 4, half-maximal cytotoxic concentration: 25000 nM
For compound 4 middle estimate and measured number coincide at the digits printed; low and high end bracket the measured number.
By their numbers in this assay, from the lowest: compounds 1, 2, 3 and 4 (each within the scatter of the next).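

Among the compounds shown here, replacing benzyl with 1-(4-methylphenyl)ethyl on a nitrogen on an aromatic ring gives no change at the digits printed from compound 3 to compound 4 (within the scatter) in this assay and is the first measured step that alters the benzyl group itself. Compound 4 also reads against the other two substituents, with no change at the digits printed from compound 2 to compound 4 (within the scatter) and no change at the digits printed from compound 1 to compound 4 (within the scatter), so all four groups at this position, including the one with 1 defined stereocentre, share one printed value. Nothing measured accounts for this shared value.

Open, from the compounds shown here alone, is whether a carboxylic acid or a primary amine on the chain at this position would shift the reading, and whether the opposite stereocentre in the 1-(4-methylphenyl)ethyl group would read the same. Also open, going by these compounds, is how replacing the hydroxymethyl group on the shared core with a plain methyl would read.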